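Methyl for trifluoromethyl on the phenyl ring

The source may report more compounds than this note shows. Statements on the series, on what has been measured and on what is new or still open speak of the compounds shown alone.

Compound 1, `Cc1c(CN2CCCC2)cc(-c2ccccc2)n1Nc1ccnc2cc(Cl)ccc12`, in a physicochemical assay for lipophilicity, at pH 7.4; on this read-out higher numbers stand for higher lipophilicity and lower numbers for lower lipophilicity: 3.28
Compound 2, `Cc1c(CN2CCCC2)cc(-c2ccc(C(F)(F)F)cc2)n1Nc1ccnc2cc(Cl)ccc12`, in this assay: 4.72

Among the measured compounds shown here, compound 2 stands highest of the two values measured so far; its nearest neighbour is compound 1, and the step of a number 1.44 log units higher from compound 1 to compound 2 (beyond the scatter) separates them. Compound 3 is `Cc1ccc(-c2cc(CN3CCCC3)c(C)n2Nc2ccnc3cc(Cl)ccc23)cc1`; it differs from compound 2 by methyl in place of trifluoromethyl on an aromatic carbon. For the measured compounds named here, the only measured step that bears on this change is a number 1.44 log units higher from compound 1 to compound 2 (beyond the scatter), which shows how much the group now leaving had added. With a methyl in its place the number is expected to fall back part of the way, a step of a number 0.92 log units lower from compound 2 to compound 3 (beyond the scatter). Compound 3 is therefore estimated at 3.8, with a range from 3.4 to 4.3.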

Compound 3, distribution coefficient: 3.91
Compound 3: middle estimate off by 0.11 log units, on the low side, within the range that was stated.
By their numbers in this assay, from the lowest: compound 1; then compound 3; then compound 2.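

At this position, this assay now separates hydrogen, methyl and trifluoromethyl into three distinct levels. Methyl in place of hydrogen gives a number 0.63 log units higher from compound 1 to compound 3 (beyond the scatter), and methyl in place of trifluoromethyl gives a number 0.81 log units lower from compound 2 to compound 3 (beyond the scatter), so compound 3 lies clearly apart from both neighbours rather than matching either. Nothing available explains the sizes of these steps. Where a methoxy group, a nitrile or a carboxylic acid at this position would fall remains open. So does whether a chlorine atom would land near methyl or near trifluoromethyl.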